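The source may hold more compounds than are shown below. What is called first, only, known or untested is meant among the compounds shown, and "the series" means these compounds.

Measured compounds in the series:

Compound 1, `CCC(=O)NC(c1ccco1)c1cc(Cl)c2cccnc2c1O`, in an assay for inhibition of Polyunsaturated fatty acid lipoxygenase ALOX12 (Homo sapiens), read by spectrophotometry (a higher number here means a weaker inhibitor, a lower number a stronger inhibitor), gives 1000 nM.
Compound 3, `CCC(=O)NC(c1ccc(C)s1)c1cc(Cl)c2cccnc2c1O`, gives 3500 nM in this assay.
Compound 2, `CC(=O)NCc1cc(Cl)c2cccnc2c1O`, reaches only the limit of > 150000 nM in this assay; this is a limit of the assay and not a number.

Going by the values given here, compound 3 stands at the highest of the two numbers given; its nearest neighbour is compound 1, and the single step between them, a 3.5-fold higher number from compound 1 to compound 3 (0.54 log units; beyond the scatter), is a modest one that lies beyond the scatter. The one limit, (the limit of > 150000 nM in this assay, at which 1 of the 3 values shown sits), belongs to compound 2, which carries no aryl group on the chain carbon and is not a close comparison for the present step.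

Compound 4, `CCC(=O)NC(c1ccc(F)cc1)c1cc(Cl)c2cccnc2c1O`, is not yet measured. The change from compound 3 is 4-fluorophenyl in place of 5-methylthiophen-2-yl on a saturated chain carbon bound to an amide-type nitrogen and an aromatic carbon. Among the compounds with values here, the only measured step that bears on a swap of the aryl group at this chain carbon is the one from compound 1 to compound 3, and it was modest. Within the data shown here, no measured step tells how a six-membered carbon-only ring behaves at this place. The working expectation is therefore a step of a 1.4-fold lower number from compound 3 to compound 4 (0.15 log units; within the scatter), within the scatter or a little below it. Compound 4 is estimated at 2500 nM in this assay, with a range from 800 nM to 8000 nM.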

Compound 4, half-maximal inhibitory concentration: > 50000 nM
Compound 4: no number, only a limit; the forecaster's own chance of this, stated with the estimate: 5%; at least 20-fold (1.30 log units) between middle value and limit.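

Compound 4 reaches only a limit of the assay and not a number: the limit of > 50000 nM in this assay, at which 1 of the 4 values shown sits.

At the saturated chain carbon bound to an amide-type nitrogen and an aromatic carbon, the aryl groups are far from interchangeable: 4-fluorophenyl in place of 5-methylthiophen-2-yl gives an at least 14-fold higher number from compound 3 to compound 4 (1.15 log units; beyond the scatter), and 4-fluorophenyl in place of furan-2-yl gives an at least 50-fold higher number from compound 1 to compound 4 (1.69 log units; beyond the scatter), whereas the earlier swap of one five-membered ring for another gave only a 3.5-fold higher number from compound 1 to compound 3 (0.54 log units; beyond the scatter). Among these three compounds, the two with a five-membered aromatic ring at this place give numbers in this assay, while the one with a six-membered aromatic ring of carbon only does not, so this place tolerates less change than the first pair could show.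

The compounds shown do not separate the effect of the six-membered ring from that of the fluorine: plain phenyl and pyridin-2-yl at the same carbon would address that question. They also leave unresolved how the sulfur and the methyl each contribute to the step from furan-2-yl to 5-methylthiophen-2-yl, which plain thiophen-2-yl would help to resolve.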